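A few compounds are considered here, and "the series" means these few. Any claim that something is new, unique, unknown or untested is made for them only; others in the source may bear on it.

Of the compounds shown here, three built on one shared core have so far been tested in a functional assay on MDA-MB-231 cells (Homo sapiens) for cytotoxicity, read by MTT assay, with a stated time of 48 h; a lower number here means a stronger inhibitor, a higher number a weaker inhibitor. Compound 1 `O=C(NC1CCCCC1)c1cc(Oc2cccc(NC(=S)Nc3ccc(F)c(F)c3)c2)ccn1` reaches only the limit of this assay, reported as > 100000 nM. Compound 2 `CNC(=O)c1cc(Oc2cccc(NC(=S)Nc3cccc(C(F)(F)F)c3)c2)ccn1` likewise gives a limit, > 100000 nM. For the measured compounds named here, compound 3 `O=C(NC1CC1)c1cc(Oc2cccc(NC(=S)Nc3cccc(C(F)(F)F)c3)c2)ccn1` is the only one with an actual number, 34800 nM. The step of an at least 2.8-fold lower number from compound 2 to compound 3 (0.45 log units; beyond the scatter) shows that replacing methyl by cyclopropyl on the amide nitrogen moved the value out of the limit region into a measurable one.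

Compound 4 `O=C(NC1CCCCC1)c1cc(Oc2cccc(NC(=S)Nc3cccc(C(F)(F)F)c3)c2)ccn1` carries the change (cyclohexyl in place of cyclopropyl on an amide-type nitrogen). Going by the values given here, no measured pair isolates this change. Compound 1 also bears a cyclohexyl on its amide nitrogen, yet it differs from compound 4 in the aryl of the thiourea as well, so its value cannot be read as a step; it merely stands at the limit of > 100000 nM in this assay, at which 2 of the 3 values shown sit. The one measured step in this assay rewarded growth from methyl to cyclopropyl, but whether growth to cyclohexyl continues that trend or reverses it is not told by any pair shown. The expected step of a 1.7-fold higher number from compound 3 to compound 4 (0.24 log units; within the scatter) is therefore a modest rise toward weaker inhibition, with a real chance of a limit. Compound 4 is expected to give about 60000 nM, within a range from 15000 nM to 200000 nM.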

Compound 4, half-maximal inhibitory concentration: > 100000 nM
Compound 4 ended at the assay's limit; the forecaster's own chance of this, stated with the estimate: 40%; middle value at least 1.6-fold (0.22 log units) from the limit.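

In this assay, the amide nitrogen does not reward ever larger rings: cyclohexyl in place of cyclopropyl gives an at least 2.8-fold higher number from compound 3 to compound 4 (0.45 log units; beyond the scatter), so the gain seen with cyclopropyl is lost again. The result for compound 4 is a limit, not a number, and the true size of this step could therefore be greater than printed; with the 3-(trifluoromethyl)phenyl thiourea held fixed, cyclopropyl in compound 3 is now the only one of the three amide groups that gives a measurable value, with methyl in compound 2 and cyclohexyl in compound 4 both failing to do so. The steps to compound 4 from compound 2 and from compound 1 cannot be read, since both ends of each are limits: the limit of > 100000 nM in this assay, at which 3 of the 4 values shown sit.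

Still open, on these data alone, is where between cyclopropyl and cyclohexyl the measurable value disappears, which a cyclobutyl or cyclopentyl ring on the amide nitrogen, or an open isopropyl group, could help to place. Also open, as far as these compounds go, is whether the 3,4-difluorophenyl group of compound 1 would give a measurable value when paired with cyclopropyl on the amide nitrogen.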